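Bromo-triazolothiadiazoles against L1210 cells: swapping the aryl group

The source may report more compounds than this note shows. Statements on the series, on what has been measured and on what is new or still open speak of the compounds shown alone.

Compound 1 `Clc1ccc(Cc2nn3cc(-c4ccc(Cl)cc4Cl)nc3s2)cc1` — 247000 nM
Compound 2 `Clc1ccc(Cc2nn3c(Br)c(-c4ccc(Cl)cc4)nc3s2)cc1` — > 250000 nM
Compound 3 `COc1ccc(-c2nc3sc(Cc4ccc(Cl)cc4)nn3c2Br)cc1` — 63000 nM

Of the compounds shown here, three sharing one core have been tested in a functional assay on L1210 cells (Mus musculus) for cytotoxicity, with a stated time of 48 h; on this read-out lower numbers stand for stronger inhibition and higher numbers for weaker inhibition. Compound 1 gives 247000 nM in this assay. For compound 2 the result in this assay is only a limit, > 250000 nM, not a number. Compound 3 gives 63000 nM in this assay, the lowest of the two numbers shown, with compound 1 the nearest at a higher value.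

Among the measured compounds shown here, the one measured step, an at least 3.9-fold lower number from compound 2 to compound 3 (0.59 log units; beyond the scatter), shows that methoxy in place of chloro on the aryl group lowers the number, beyond the scatter; this rests on the limit (the limit of > 250000 nM in this assay, at which 1 of the 3 values shown sits).

Compound 4 `Clc1ccc(Cc2nn3c(Br)c(-c4ccc(Cl)cc4Cl)nc3s2)cc1` reverses that direction: 2,4-dichlorophenyl in place of 4-methoxyphenyl on an aromatic carbon. Compound 1, which carries the same 2,4-dichlorophenyl without the bromo group, gives 247000 nM. The step from compound 3 to compound 4 is therefore expected to raise the number, a 4.0-fold higher number from compound 3 to compound 4 (0.60 log units; beyond the scatter), in this assay. Compound 4 is estimated at 250000 nM, within 80000 nM to 700000 nM, with a fair chance that only a limit is reported.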

Compound 4, half-maximal inhibitory concentration: 31000 nM
Estimate against measurement, compound 4: 8.1-fold (0.91 log units) above, and the stated range ends above it.
By their numbers in this assay, from the lowest: compound 4; then compound 3; then compound 1. At a limit, above all of these: compound 2.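

In this assay, the aryl group at this position does not rank simply as chloro against methoxy: a 2.0-fold lower number from compound 3 to compound 4 (0.31 log units; beyond the scatter), the opposite direction to the earlier step from a single chloro to methoxy. A further chloro on the aryl group gives an at least 8.0-fold lower number from compound 2 to compound 4 (0.90 log units; beyond the scatter), a step that rests on the limit reported for compound 2: the limit of > 250000 nM in this assay, at which 1 of the 4 values shown sits. The bromo group can now also be read with the 2,4-dichlorophenyl held fixed, and it gives an 8.0-fold lower number from compound 1 to compound 4 (0.90 log units; beyond the scatter).

Bromo in place of hydrogen is seen only with 2,4-dichlorophenyl, so whether the same change would lower the number with 4-methoxyphenyl stays open. Also open, as far as these compounds go, is how an amine or a carboxylic acid on the aryl ring, or a longer chain in place of the bromo group, would read in this assay.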